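The compounds below may be only part of what the source reports. "The series", "measured", "known", "first", "only" and "open" are said of these compounds alone.

Compounds tested so far in a functional assay on HepG2 cells (Homo sapiens) for cytotoxicity, read by MTT assay, with a stated time of 48 h; a lower number here means a stronger inhibitor, a higher number a weaker inhibitor

Compound 1 `CCN(CC)Cc1ccc2oc(-c3ccc(Cl)cc3)cc(=O)c2c1` gives "not determined" (no result reported)
Compound 2 `CCN(CC)Cc1ccc2c(=O)cc(-c3ccccc3Cl)oc2c1` gives 10700 nM
Compound 3 `Cc1cc(Cl)cc2c(=O)cc(-c3ccccc3Cl)oc12` gives "not determined" (no result reported)

Compound 3 thus has no single number to stand on, and compound 1 has none either. Only compound 2 supplies a figure. Compound 4 `O=c1cc(-c2ccccc2Cl)oc2c(CN3CCCCC3)cc(Cl)cc12` has yet to be measured. The change is piperidin-1-yl in place of hydrogen on a saturated chain carbon bound to an aromatic carbon, which reads as methyl to (piperidin-1-yl)methyl. With no measured starting point, the size of this step in this assay cannot be read, and no direction is expected with confidence. Going by the values given here, the only guide is compound 2 at 10700 nM, so a result in that region is expected. Compound 4 is estimated at 12000 nM, with an expected range from 4000 nM to 40000 nM.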

Compound 4, half-maximal inhibitory concentration: 10700 nM
Compound 4: the middle estimate sits 1.1-fold (0.05 log units) above what was measured; low and high end bracket the measured number.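

Compound 3 has no single number in this assay and the step to compound 4 cannot be read. The compounds shown leave open how methyl and (piperidin-1-yl)methyl compare in this read-out. No evidence bears on this result.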